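From Fluoro to Bromo on the Phenyl Ring

This account rests on a few compounds, and the source may have more. Where it says the series, first, only, none or still open, it means among the compounds named here.

Compound 1 `COc1cc2ncnc(Nc3ccc(CS(=O)(=O)/C=C/c4ccc(Cl)cc4Cl)cc3)c2cc1OC`: 2000 nM
Compound 2 `COc1cc2ncnc(Nc3ccc(CS(=O)(=O)/C=C/c4ccc(F)cc4)cc3)c2cc1OC`: > 100000 nM

In a functional assay on OVCAR-8 cells (Homo sapiens) (a higher number here means a weaker inhibitor of growth, a lower number a stronger inhibitor of growth), compound 1 gives 2000 nM. Compound 2 gives > 100000 nM, which is a limit of the assay and not a number. Compound 2 therefore has no exact position, and any step away from it is uncertain.

Compound 3 `COc1cc2ncnc(Nc3ccc(CS(=O)(=O)/C=C/c4ccc(Br)cc4)cc3)c2cc1OC` keeps the shared core and differs from compound 2 in a single substituent: bromo in place of fluoro on an aromatic carbon. This is bromo in place of fluoro on an aromatic carbon, para to a large group.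

Among the compounds with values here, one measured step bears on this change: an at least 50-fold higher number from compound 1 to compound 2 (1.69 log units; beyond the scatter). That step is large and lies beyond the scatter. It replaces 2,4-dichlorophenyl with 4-fluorophenyl, so it shows that the halogens on this ring can matter greatly, although it does not test bromo itself. A sizeable move towards lower numbers is therefore expected, but compound 3 could also remain at the limit. The expected size of the change is an at least 6.6-fold lower number from compound 2 to compound 3 (0.82 log units; beyond the scatter).

For compound 3 the estimate is 15000 nM, with an expected range from 3000 nM to 80000 nM.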

Compound 3, concentration for 50% growth inhibition: 6000 nM
Compound 3: the middle estimate sits 2.5-fold (0.40 log units) above what was measured; the measured number falls inside the stated range.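

In this assay, exchanging fluoro for bromo at this one place, with nothing else altered, gives an at least 16-fold lower number from compound 2 to compound 3 (1.22 log units; beyond the scatter), so the identity of this single halogen alone separates a compound with a measurable value from one without. Compound 2 stands at a limit of the assay, so this step has a known minimum size but no exact one: the limit of > 100000 nM in this assay, at which 1 of the 3 values shown sits. Replacing 2,4-dichlorophenyl with 4-bromophenyl has a much smaller effect, giving a 3.0-fold higher number from compound 1 to compound 3 (0.48 log units; beyond the scatter), which shows that a ring with a single bromo keeps much of the activity of the dichlorinated ring, though compound 1 remains the stronger inhibitor of growth.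

The compounds shown do not reveal whether a halogen is needed at this place at all, or whether a chloro, a methyl, a methoxy or a nitrile there would perform as well as bromo. They also leave open how much each of the two chloro groups of compound 1 contributes, and why bromo and fluoro differ so sharply here.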